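A few compounds are considered here, and "the series" means these few. Any claim that something is new, unique, unknown or untested is made for them only; others in the source may bear on it.

In a functional assay on SGC-7901 cells (Homo sapiens) for inhibition, read by MTT assay, with a stated time of 24 h (a lower number here means a stronger inhibitor, a higher number a weaker inhibitor), compound 1 (`CC1(C)[C@H]2CC[C@]1(C)N(Cc1cn(-c3ccccc3C#N)nn1)C(=O)C2`) gives 260 nM and cannot be separated from its two measured relatives, since compound 2 (`CC1(C)[C@H]2CC[C@]1(C)N(Cc1cn(-c3ccccc3F)nn1)C(=O)C2`) gives 300 nM and compound 3 (`CC1(C)[C@H]2CC[C@]1(C)N(Cc1cn(-c3cccc(Cl)c3)nn1)C(=O)C2`) gives 510 nM within the scatter. Compound 4 (`CC1(C)[C@H]2CC[C@]1(C)N(Cc1cn(-c3ccccc3)nn1)C(=O)C2`) carries hydrogen in place of cyano on an aromatic carbon, leaving a plain phenyl. Two measured changes bear on this. Swapping cyano for fluoro gave a 1.2-fold higher number from compound 1 to compound 2 (0.06 log units; within the scatter), and swapping 2-cyanophenyl for 3-chlorophenyl gave a 2.0-fold higher number from compound 1 to compound 3 (0.29 log units; within the scatter). With both steps inside the scatter, no step beyond it is expected in this assay for this removal. The expected change is small (a 1.3-fold higher number from compound 1 to compound 4 (0.13 log units; within the scatter)). For compound 4 the estimated value is 350 nM, with an expected range from 170 nM to 700 nM.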

Compound 4, half-maximal inhibitory concentration: 240 nM
For compound 4 the middle estimate is 1.5-fold (0.16 log units) above the measured one, within the range that was stated.
By their numbers in this assay, from the lowest: compounds 4, 1, 2 and 3 (each within the scatter of the next, the first and the last beyond it).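

In this assay the plain phenyl of compound 4 cannot be told apart from the 2-cyanophenyl (a 1.1-fold lower number from compound 1 to compound 4 (0.03 log units; within the scatter)) or the 2-fluorophenyl (a 1.3-fold lower number from compound 2 to compound 4 (0.10 log units; within the scatter)), so among these compounds this aromatic carbon needs no substituent to keep the activity. Hydrogen in place of chloro gives the only step beyond the scatter, and a modest one (a 2.1-fold lower number from compound 3 to compound 4 (0.33 log units; beyond the scatter)). Nothing measured here explains these numbers. As far as these compounds go, whether an amine, a carboxylic acid or a longer chain on this aromatic carbon would shift the number beyond the scatter stays open.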